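Compound 3 to compound 4: a two-ring group for 3-methylphenyl

The source may hold more compounds than are shown below. What is called first, only, known or untested is meant among the compounds shown, and "the series" means these compounds.

Values so far in a functional assay on MCF7 cells (Homo sapiens) for inhibition, read by CCK-8 assay, with a stated time of 48 h (a higher number here means a weaker inhibitor, a lower number a stronger inhibitor), for the series:
- compound 1 `COc1cc(-c2ccnc3cc(-c4c[nH]c5ccccc45)nn23)cc(OC)c1OC` gives 85 nM
- compound 2 `COc1cc(-c2ccnc3cc(-c4ccc(C(F)(F)F)cc4)nn23)cc(OC)c1OC` gives 2440 nM
- compound 3 `COc1cc(-c2ccnc3cc(-c4cccc(C)c4)nn23)cc(OC)c1OC` gives 1080 nM

Compound 3 holds the second highest of the three numbers. Compound 4 `COc1cc(-c2ccnc3cc(-c4ccc5cnn(C)c5c4)nn23)cc(OC)c1OC` carries 1-methyl-1H-indazol-6-yl in place of 3-methylphenyl on an aromatic carbon of the shared core. Among the measured compounds shown here, two measured steps bear on this change. The large step of a 13-fold higher number from compound 1 to compound 3 (1.10 log units; beyond the scatter) links 1H-indol-3-yl with 3-methylphenyl, while the modest step of a 2.3-fold lower number from compound 2 to compound 3 (0.35 log units; beyond the scatter) separates the two substituted phenyl groups. The entering group resembles the 1H-indol-3-yl of compound 1 only in part, so a moderate step toward a lower number is expected in this assay rather than the full size of the large step. The expected step is a 3.6-fold lower number from compound 3 to compound 4 (0.56 log units; beyond the scatter) for now. The estimate for compound 4 is 300 nM (expected range 80 nM to 1200 nM).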

Compound 4, half-maximal inhibitory concentration: 279 nM
Compound 4: middle estimate off by 1.1-fold (0.03 log units), on the high side, and the stated range covers the measured number.
By their numbers in this assay, from the lowest: compound 1; then compound 4; then compound 3; then compound 2.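

In this assay, the aromatic carbon of the shared core tolerates a second fused ring: 1-methyl-1H-indazol-6-yl improves on both phenyl groups (a 3.9-fold lower number from compound 3 to compound 4 (0.59 log units; beyond the scatter); an 8.7-fold lower number from compound 2 to compound 4 (0.94 log units; beyond the scatter)). Two rings alone do not match 1H-indol-3-yl, however (a 3.3-fold higher number from compound 1 to compound 4 (0.52 log units; beyond the scatter)). Nothing here explains these steps.

On these data alone, it remains open whether the gain depends on the ring nitrogens, the methyl group or the attachment point of the indazole. A 1H-indazol-6-yl without the methyl, or a naphthyl group, would help separate these.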